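Methylation of the amine in the 3-aminopropyl side chain

A few compounds are considered here, and "the series" means these few. Any claim that something is new, unique, unknown or untested is made for them only; others in the source may bear on it.

Compound 1 `NCCCNc1c(C(=O)NCc2ccc(F)cc2)nc(Br)c2cccnc12` carries a 3-aminopropyl group on the core. In a functional assay on HCT-116 cells (Homo sapiens) for cytotoxicity, read by MTT assay, with a stated time of 72 h (on this read-out lower numbers stand for stronger inhibition and higher numbers for weaker inhibition), compound 1 gives 18000 nM, the highest of the two numbers shown in this set. Compound 3 `Nc1ccc(Nc2c(C(=O)NCc3ccc(F)cc3)nc(Br)c3cccnc23)cc1`, with 4-aminophenyl in place of 3-aminopropyl on a nitrogen on an aromatic ring, gives 7000 nM; the step of a 2.6-fold lower number from compound 1 to compound 3 (0.41 log units; beyond the scatter) is modest and beyond the scatter. Compound 2 `CC(C)(C)OC(=O)N1CCN(c2c(C(=O)NCc3ccc(F)cc3)nc(Br)c3cccnc23)CC1` returns only a limit of this assay, > 10000 nM, and stands apart from the comparison (the limit of > 10000 nM in this assay, at which 1 of the 3 values shown sits).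

Compound 4 `CNCCCNc1c(C(=O)NCc2ccc(F)cc2)nc(Br)c2cccnc12` differs from compound 1 by methyl in place of hydrogen on an amine nitrogen. Going by the values given here, no measured step touches this position: the one measured step, from compound 1 to compound 3, swaps the whole amine substituent rather than adding a single methyl on its nitrogen, and so it says only that changes in this part of the molecule move the number modestly. On that basis a step of no more than the scatter is expected for compound 4, with no clear direction, and the number is estimated to lie near that of compound 1. The expected step is a 1.2-fold lower number from compound 1 to compound 4 (0.08 log units; within the scatter), giving an estimate for compound 4 of 15000 nM, with a range from 6000 nM to 40000 nM.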

Compound 4, half-maximal inhibitory concentration: > 10000 nM
Compound 4: a limit, no number; the forecaster's own chance of this, stated with the estimate: 25%; the middle value does not contradict the limit.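

The added methyl on the amine nitrogen gives no number at this position: compound 4 returns only a limit in this assay, > 10000 nM. The step from compound 1 therefore cannot be read, in either size or direction, so this result does not show whether the methyl matters here. Going by these compounds alone, the one readable comparison is an at least 1.4-fold higher number from compound 3 to compound 4 (0.15 log units; that floor lies within the scatter), and that floor alone does not separate 3-(methylamino)propyl from 4-aminophenyl on a nitrogen on an aromatic ring, so the modest gap seen earlier with the unmethylated chain is neither confirmed nor contradicted. Compound 2 and compound 4 now both give no number in this set:  the limit of > 10000 nM in this assay, at which 2 of the 4 values shown sit.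

On these data alone, whether a methyl on this amine nitrogen moves the number at all, and which way, remains open. Also open, as far as these compounds go, is how a dimethylamino end group, an ethyl group on the same nitrogen, or a longer chain in place of 3-aminopropyl would read in this assay.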